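Ortho-methoxybenzyl indazole: expectation from two chlorobenzyl analogues

The source may hold more compounds than are shown below. What is called first, only, known or untested is meant among the compounds shown, and "the series" means these compounds.

Measured compounds:
compound 1 `CCOC(=O)c1cccc(-c2n[nH]c3ccccc23)c1` gives 5650 nM in a functional assay on cells (Platelet, Homo sapiens) for inhibition; on this read-out higher numbers stand for weaker inhibition and lower numbers for stronger inhibition
compound 2 `CCOC(=O)c1ccc(-c2nn(Cc3ccccc3Cl)c3ccccc23)cc1` gives 230 nM in this assay
compound 3 `CCOC(=O)c1ccc(-c2nn(Cc3ccc(Cl)cc3)c3ccccc23)cc1` gives 120 nM in this assay

Compound 3 has the lowest of the three numbers. Its nearest neighbour is compound 2, whose number sits within the scatter of repeated measurement, so the two cannot be ordered; compound 1, which carries no group on the ring nitrogen, lies far above both and is the only one clearly separated.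

Compound 4 `CCOC(=O)c1ccc(-c2nn(Cc3ccccc3OC)c3ccccc23)cc1` differs from compound 3 in one place: 2-methoxyphenyl in place of 4-chlorophenyl on a saturated chain carbon bound to an aromatic nitrogen. Within the data shown here, only one measured step touches the same position, the change of 4-chlorophenyl in place of 2-chlorophenyl on a saturated chain carbon bound to an aromatic nitrogen, which gave a 1.9-fold lower number from compound 2 to compound 3 (0.28 log units; within the scatter). That step shows that moving a chlorine around the ring changed little. Among the measured compounds shown here, no measured compound bears a methoxy group, so the effect of the entering group is untested, and the one relevant step is small. The step from compound 3 to compound 4 is therefore expected to be a 1.8-fold higher number from compound 3 to compound 4 (0.26 log units; within the scatter), with a wide margin. Compound 4 is estimated at 220 nM, between 70 nM and 700 nM.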

Compound 4, half-maximal inhibitory concentration: 470 nM
Beside the measured number, compound 4's estimate is 2.1-fold (0.33 log units) below it; measured number inside the range.
By their numbers in this assay, from the lowest: compounds 3 and 2 (each within the scatter of the next); then compound 4; then compound 1.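

In this assay, the change from 4-chlorophenyl to 2-methoxyphenyl on a saturated chain carbon bound to an aromatic nitrogen gives a 3.9-fold higher number from compound 3 to compound 4 (0.59 log units; beyond the scatter), so this place responds to a change of group by more than the scatter, which the step between the two chlorobenzyl compounds did not show. The comparison with the 2-chlorophenyl compound is narrower, as methoxy in place of chloro on an aromatic carbon gives a 2.0-fold higher number from compound 2 to compound 4 (0.31 log units; beyond the scatter), a modest step that only just clears the scatter. Nothing available explains why methoxy gives the higher number in either comparison.

The step from compound 3 to compound 4 changes both the group and where it stands, and a 4-methoxyphenyl group would be needed to separate those two changes. The compounds shown also leave open how this place would respond to an amine or a carboxylic acid on the benzyl ring, or to a longer chain between that ring and the aromatic nitrogen.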